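A few compounds are considered here, and "the series" means these few. Any claim that something is new, unique, unknown or untested is made for them only; others in the source may bear on it.

Compound 1, `CC(C)Cn1nc(C(=O)N[C@H]2COc3ccccc3N(C)C2=S)nc1Cc1ccccc1`, in a toxicity assay on HT-29 cells (Homo sapiens) for cytotoxicity (a higher number here means that more compound is tolerated, a lower number that less compound is tolerated), gives > 100000 nM, which is a limit of the assay and not a number.
Compound 2, `CN1C(=S)[C@@H](NC(=O)c2nc(Cc3ccccc3)n(CCCC(F)(F)F)n2)COc2ccccc21`, in this assay gives > 100000 nM, again a limit rather than a number.

Among the compounds with values here, compound 2 therefore stands at the limit of this assay, and the only other value shown sits at the same limit, so no ordering between the two measured compounds can be read from these figures. Within the data shown here, the single measured step, a step that the two limits leave unreadable from compound 1 to compound 2, is one that the two limits leave unreadable in size.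

Compound 3, `CN1C(=S)[C@@H](NC(=O)c2nc(Cc3ccccc3)n(CC3CCOCC3)n2)COc2ccccc21`, has not yet been measured in this assay. Its structural change from compound 2 is oxan-4-yl in place of 3,3,3-trifluoropropyl on a saturated chain carbon bound to an aromatic nitrogen. Among the measured compounds shown here, the only measured step that touches this position is the unreadable one from compound 1 to compound 2, and the relevant evidence is the limit of > 100000 nM in this assay, at which 2 of the 2 values shown sit, so no direction or size can be drawn for the present change. With both measured values sitting at the limit, compound 3 is expected to remain at or near that limit, and the step of a number no higher from compound 2 to compound 3 (the limit leaves the size open) is estimated to be none beyond the scatter. Compound 3 is thus expected to give about 100000 nM in this assay, within a range of 40000 nM to 250000 nM.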

Compound 3, half-maximal cytotoxic concentration: > 100000 nM
Compound 3 ended at the assay's limit; the forecaster's own chance of this, stated with the estimate: 85%; the middle value sits exactly at the limit.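

Compound 3 joins compound 1 and compound 2 at the limit of this assay, so no step among the three can be read, in size or in direction: the limit of > 100000 nM in this assay, at which 3 of the 3 values shown sit.

The compounds shown leave open whether isopropyl, 3,3,3-trifluoropropyl and oxan-4-yl differ at all in this assay, and at what concentration any of the three would reach a half-maximal cytotoxic effect.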